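The source may hold more compounds than are shown below. What is called first, only, known or untested is meant among the compounds shown, and "the series" means these compounds.

The measured compounds:
compound 1 `O=C(Nc1cccc(-n2cc(-c3ccncc3)c(-c3ccc(Cl)c(O)c3)n2)c1)Nc1cccc(C(F)(F)F)c1`: 7260 nM
compound 2 `COc1cc(-c2nn(-c3cccc(NC(=O)Nc4ccc(Cl)c(Cl)c4)c3)cc2-c2ccncc2)ccc1Cl`: 1560 nM
compound 3 `O=C(Nc1cccc(-n2cc(-c3ccncc3)c(-c3ccc(Cl)c(O)c3)n2)c1)Nc1ccc(Cl)c(Cl)c1`: 2890 nM

All three were run in a functional assay on HCC 2998 cells (Homo sapiens) for inhibition, read by sulforhodamine B assay, with a stated time of 48 h; on this read-out higher numbers stand for weaker inhibition of growth and lower numbers for stronger inhibition of growth. Compound 2 gives 1560 nM, the lowest of the three numbers; compound 3 with 2890 nM sits within the scatter of it, while compound 1 with 7260 nM lies beyond the scatter. Two single-point steps connect them. a 2.5-fold lower number from compound 1 to compound 3 (0.40 log units; beyond the scatter). a 1.9-fold higher number from compound 2 to compound 3 (0.27 log units; within the scatter).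

Compound 4 `COc1cc(-c2nn(-c3cccc(NC(=O)Nc4ccc(Cl)c(C(F)(F)F)c4)c3)cc2-c2ccncc2)ccc1Cl` has not yet been measured in this assay. It differs from compound 2 in one place: trifluoromethyl in place of chloro on an aromatic carbon. Going by the values given here, the step that bears on this is the one between compound 1 and compound 3, which exchanged a trifluoromethyl-bearing phenyl for a dichlorophenyl on the same amide-type nitrogen and read a 2.5-fold lower number from compound 1 to compound 3 (0.40 log units; beyond the scatter). That comparison is only partial, since compound 4 keeps one chloro and adds trifluoromethyl, so only a modest step in this assay is expected, if anything toward a higher number. Compound 4 is therefore estimated at 2200 nM, in a range from 900 nM to 5500 nM. The expected step is a 1.4-fold higher number from compound 2 to compound 4 (0.15 log units; within the scatter).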

Compound 4, concentration for 50% growth inhibition: 1550 nM
Estimate against measurement, compound 4: 1.4-fold (0.15 log units) above, within the range that was stated.
By their numbers in this assay, from the lowest: compounds 4, 2 and 3 (each within the scatter of the next); then compound 1.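

In this assay, trifluoromethyl in place of chloro on an aromatic carbon, ortho to a chloro group, gives a 1.0-fold lower number from compound 2 to compound 4 (0.00 log units; within the scatter), so at this position a group of four heavy atoms stands in for one of a single heavy atom with no difference that can be told from the scatter. Going by these compounds alone, the earlier step, a 2.5-fold lower number from compound 1 to compound 3 (0.40 log units; beyond the scatter), lay beyond the scatter, but it compared a ring without the 4-chloro group to the 3,4-dichlorophenyl ring, and with that chloro kept, as in the 4-chloro-3-(trifluoromethyl)phenyl ring of compound 4, the exchange of the neighbouring group alone shows no such step on the methyl-capped oxygen series. Nothing measured here explains why the exchange reads this way.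

The compounds shown leave open whether the same exchange would read alike with hydrogen in place of methyl on the oxygen, and whether the chloro group kept in compound 4 is what separates the two earlier compounds. They also leave open how this position would read with a nitrile, a methyl or an amine in place of trifluoromethyl.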